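The compounds below may be only part of what the source reports. "The series", "measured", "known", "first", "only" and "open" are said of these compounds alone.

Measured so far:
compound 1 `CCCC(=O)Nc1ccc(Sc2cccc(OC)c2)cc1` — 29 nM
compound 2 `COc1cccc(N(C)c2ccc(NC(C)=O)cc2)c1` — 0.05 nM

In an assay on isolated protein for binding affinity to melatonin receptor type 1A (Homo sapiens) (a higher number here means a weaker inhibitor, a lower number a stronger inhibitor), compound 2 gives 0.05 nM, the lowest of the two numbers; the nearest is compound 1, whose number is far higher, well beyond the scatter. The step goes from compound 2 to compound 3 `CCOC(=O)Nc1ccc(N(C)c2cccc(OC)c2)cc1`, not yet measured in this assay. The change is ethoxy in place of methyl on a carbonyl carbon, so that the acetamido of compound 2 becomes an (ethoxycarbonyl)amino in compound 3. Within the data shown here, no step between measured compounds is known for this change, so the direction has to be guessed: a moderate rise in the inhibition constant, beyond the scatter but short of a large one, is expected, since compound 2 starts at 0.05 nM and leaves little room for a lower number. Compound 3 is therefore estimated at 0.3 nM, within 0.05 nM to 3 nM, an expected step of a 6.0-fold higher number from compound 2 to compound 3 (0.78 log units; beyond the scatter).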

Compound 3, inhibition constant: 34 nM
For compound 3 the middle estimate is 110-fold (2.05 log units) below the measured one, outside the stated range (above it).
By their numbers in this assay, from the lowest: compound 2; then compounds 1 and 3 (each within the scatter of the next).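

In this assay, among these compounds, this position on the carbonyl carbon proves highly sensitive: ethoxy in place of methyl gives a 680-fold higher number from compound 2 to compound 3 (2.83 log units; beyond the scatter) and is the first step read here. With the rest of the structure unchanged, the very low number of compound 2 does not survive the change from acetamido to (ethoxycarbonyl)amino. Nothing at hand accounts for the size of this step.

The compounds shown do not separate the effect of the oxygen that enters from that of the longer group as a whole. As far as these compounds go, a propanoyl or a methoxycarbonyl group on the same nitrogen would bear on that question, and it remains open whether any group larger than acetyl keeps a number close to that of compound 2.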